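Variation of the group on the sulfur in the shared core

A few compounds are considered here, and "the series" means these few. Any claim that something is new, unique, unknown or untested is made for them only; others in the source may bear on it.

Compound 1 `CC(C)[C@H](NC(=O)COc1cccc2ccccc12)C(=O)N[C@@H](CC(=O)O)C(=O)CSC1=NCCS1` carries a five-membered non-aromatic ring with two hetero atoms on a sulfur whose other neighbour is a saturated chain carbon. In a functional assay on Jurkat cells (Homo sapiens) for inhibition (a higher number here means a weaker inhibitor, a lower number a stronger inhibitor), compound 1 gives > 200000 nM, which is a limit of the assay and not a number. Compound 2 `CC(C)[C@H](NC(=O)COc1cccc2ccccc12)C(=O)N[C@@H](CC(=O)O)C(=O)CSc1nc(-c2ccccc2)c(-c2ccccc2)o1` bears a different substituent on the same sulfur. In this assay compound 2 gives > 200000 nM, again a limit rather than a measured value. Going by the values given here, compound 1 thus stands at the limit of > 200000 nM in this assay, at which 2 of the 2 values shown sit, and no step between measured compounds is available for this series.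

Compound 3 `CC(C)[C@H](NC(=O)COc1cccc2ccccc12)C(=O)N[C@@H](CC(=O)O)C(=O)CSc1nc2ccccc2o1` is the next member. It differs from compound 1 by a group of 9 heavy atoms (7 carbon, 1 nitrogen, 1 oxygen; one five-membered aromatic ring with 2 hetero atoms, one six-membered aromatic ring of carbon only) in place of a group of 5 heavy atoms (3 carbon, 1 nitrogen, 1 sulfur; one five-membered non-aromatic ring with 2 hetero atoms), on a sulfur. Because both measured values sit at the limit of > 200000 nM in this assay, at which 2 of the 2 values shown sit, neither direction nor size of this step can be read from the two limits; the expectation is that the change remains within the scatter, with the result most likely another limit. For compound 3 in this assay the estimated value is 200000 nM, with a range from 50000 nM to 500000 nM. The step this estimate means, a number no higher from compound 1 to compound 3 (the limit leaves the size open), is expected to be essentially none.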

Compound 3, half-maximal inhibitory concentration: > 200000 nM
Compound 3: no number, only a limit; the forecaster's own chance of this, stated with the estimate: 75%; the middle value lies on the limit itself.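

In this assay compound 3 gives > 200000 nM, a limit of the assay and not a number. Going by these compounds alone, no step from compound 1 to compound 3 can be read, because both results are limits: the limit of > 200000 nM in this assay, at which 3 of the 3 values shown sit. The compounds shown leave open which group on the sulfur, if any, would give a measurable value in this assay.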